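A Methylphenyl Swap at the Carbonyl Carbon

The compounds below may be only part of what the source reports. "The series", "measured", "known", "first", "only" and "open" are said of these compounds alone.

In a functional assay on SW982 cells (Homo sapiens) for inhibition, read by MTT assay, with a stated time of 72 h (a higher number here means a weaker inhibitor, a lower number a stronger inhibitor), compound 3 (`COc1cc(OC)c(OC)cc1/C=C/C(=O)c1ccc(O)cc1O`) gives 32400 nM. Going by the values given here, only one other compound on the shared core has a number to set beside it: compound 1 (`COc1cc(OC)c(OC)cc1/C=C/C(=O)c1ccc(Cl)cc1`) gives 58500 nM. The two values lie within the scatter of each other, as the step of a 1.8-fold lower number from compound 1 to compound 3 (0.26 log units; within the scatter) shows. Compound 2 (`COc1cc(OC)c(OC)cc1/C=C/C(=O)c1ccc(-c2c[nH]cn2)cc1`) is recorded only as a limit, > 150000 nM.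

Compound 4 (`COc1cc(OC)c(OC)cc1/C=C/C(=O)c1ccc(C)cc1`) has 4-methylphenyl in place of 2,4-dihydroxyphenyl on a carbonyl carbon. Among the compounds with values here, two measured steps bear on this change. The closer one involves compound 1 and the same carbonyl carbon, where 2,4-dihydroxyphenyl in place of 4-chlorophenyl gave a 1.8-fold lower number from compound 1 to compound 3 (0.26 log units; within the scatter). So one phenyl group exchanged for another at this place did not move the number beyond the scatter. The other step, 1H-imidazol-4-yl in place of chloro on an aromatic carbon, gave an at least 2.5-fold higher number from compound 1 to compound 2 (0.40 log units; beyond the scatter), but it ends at a limit and involves a different kind of group, so it carries less weight here.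

On this basis, no large change is expected in this assay. The expected step is a 1.5-fold higher number from compound 3 to compound 4 (0.19 log units; within the scatter), a small rise that would stay within the scatter. The estimate for compound 4 is 50000 nM, with an expected range from 22000 nM to 110000 nM.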

Compound 4, half-maximal inhibitory concentration: 81100 nM
The estimate for compound 4 lay 1.6-fold (0.21 log units) below the measured number; measured number inside the range.
By their numbers in this assay, from the lowest: compounds 3, 1 and 4 (each within the scatter of the next, the first and the last beyond it). At a limit, above all of these: compound 2.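

In this assay, going by these compounds alone, 4-methylphenyl in place of 2,4-dihydroxyphenyl on the carbonyl carbon gives the first step at this place that lies beyond the scatter: a 2.5-fold higher number from compound 3 to compound 4 (0.40 log units; beyond the scatter). The two end points are thus separated, yet compound 1 lies within the scatter of both, as a 1.8-fold lower number from compound 1 to compound 3 (0.26 log units; within the scatter) shows. With methyl in place of chloro on an aromatic carbon, the step is a 1.4-fold higher number from compound 1 to compound 4 (0.14 log units; within the scatter). Compound 2 remains a limit: the limit of > 150000 nM in this assay, at which 1 of the 4 values shown sits. Methyl in place of 1H-imidazol-4-yl on an aromatic carbon therefore gives only a floor, an at least 1.8-fold lower number from compound 2 to compound 4 (0.26 log units; that floor lies within the scatter), and the full size of this step cannot be read.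

The leaving group counts 2 hydrogen-bond donors and 2 hydrogen-bond acceptors and the entering group 0 of each, but the compounds shown cannot tell whether those counts account for the step, as every aryl group here differs from the others in more than one respect. From the compounds shown here alone, it remains open how a monohydroxyphenyl group would read on the same carbonyl carbon, and how an amine or a carboxylic acid would read in place of the methyl of compound 4.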